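A few compounds are considered here, and "the series" means these few. Any claim that something is new, unique, unknown or untested is made for them only; others in the source may bear on it.

Measured so far:
compound 1 `Cc1cc(Nc2cc(-c3ccccc3)[nH]n2)n2ncnc2n1`: > 50000 nM
compound 2 `Cc1cc(Nc2cc(-c3ccc(Cl)cc3)[nH]n2)n2nc(SCc3ccc(Br)cc3)nc2n1`: 3620 nM
compound 3 `Cc1cc(Nc2ccn(Cc3nc(C)c4ccccc4n3)n2)n2nc(SCc3ccc(Br)cc3)nc2n1`: 1430 nM

In a functional assay on MCF7 cells (Homo sapiens) for inhibition, read by MTT assay, with a stated time of 72 h (on this read-out higher numbers stand for weaker inhibition and lower numbers for stronger inhibition), compound 1 gives > 50000 nM, which is a limit of the assay rather than a measured number. Compound 1 thus sits at the limit of > 50000 nM in this assay, at which 1 of the 3 values shown sits, the weakest position that this read-out can report. Within the data shown here, compound 2 gives 3620 nM in this assay and compound 3 gives 1430 nM; both differ from compound 1 in more than one place, so no single step connects either of them to compound 1, and their values only show that substituted members can reach the measurable range.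

Compound 4 `C=CCSc1nc2nc(C)cc(Nc3cc(-c4ccccc4)[nH]n3)n2n1` is the untested member. It differs from compound 1 by allylsulfanyl in place of hydrogen on an aromatic carbon. The step of an at least 5.5-fold lower number from compound 1 to compound 4 (0.74 log units; beyond the scatter) is expected to run toward stronger inhibition and to exceed the usual scatter, though its true size cannot be fixed when compound 1 shows only a limit. Compound 4 is estimated at 9000 nM, most likely between 2000 nM and 45000 nM.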

Compound 4, half-maximal inhibitory concentration: > 50000 nM
Compound 4: a limit, no number; the forecaster's own chance of this, stated with the estimate: 25%; at least 5.5-fold (0.74 log units) between middle value and limit.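

In this assay compound 4 gives > 50000 nM, a limit of the assay and not a number. Compound 1 also stands at a limit, so no step can be read between compound 1 and compound 4: the limit of > 50000 nM in this assay, at which 2 of the 4 values shown sit. The compounds shown leave open whether allylsulfanyl in place of hydrogen on an aromatic carbon changes inhibition at all.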